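The source may hold more compounds than are shown below. What is called first, only, known or untested is meant among the compounds shown, and "the series" means these compounds.

Measured so far:
Compound 1, `CCCCCCCCCCCC(=O)N[C@H](CCC(=O)NC(CCCC(N)C(=O)O)C(=O)O)C(=O)O`: in a functional assay on HEK293 cells for agonist activity at Nucleotide-binding oligomerization domain-containing protein 1 (Homo sapiens), read by spectrophotometry (a higher number here means that more compound is needed for the effect, a lower number that less compound is needed), compound 1 gives 0.027 nM.
Compound 2, `CCCCCCCCCCCC(=O)N[C@H](CCC(=O)NC(CCCC(NC(=N)N)C(=O)O)C(=O)O)C(=O)O`: in this assay compound 2 gives 0.622 nM.
Compound 3, `CCCCCCCCCCCOC(=O)[C@H](N)CCC(=O)NC(CCCC(N)C(=O)O)C(=O)O`: in this assay compound 3 gives 0.066 nM.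

Compound 1 and compound 3 share much of their build, but the difference between their two cores is not broken down here; their values show that compound 3 needs a somewhat larger amount than compound 1, a gap beyond the scatter. Within the core of compound 1, one change has already been measured: a group of 3 heavy atoms (1 carbon, 2 nitrogen; no ring) in place of a hydrogen atom, on an amine nitrogen This change gave a 23-fold higher number from compound 1 to compound 2 (1.36 log units; beyond the scatter) in this assay.

Compound 4, `CCCCCCCCCCCOC(=O)[C@@H](CCC(=O)NC(CCCC(N)C(=O)O)C(=O)O)NC(=N)N`, has not yet been measured. It arises from compound 3 by a group of 3 heavy atoms (1 carbon, 2 nitrogen; no ring) in place of a hydrogen atom, on an amine nitrogen The place is the same in both pairs, an amine nitrogen whose other neighbour is a saturated chain carbon, so this is the same change seen once before.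

Because the earlier change produced a 23-fold higher number from compound 1 to compound 2 (1.36 log units; beyond the scatter), a step of about the same size is expected here, that is a 23-fold higher number from compound 3 to compound 4 (1.36 log units; beyond the scatter). Compound 4 is therefore estimated at 1.5 nM in this assay, with a likely range from 0.5 nM to 5 nM.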

Compound 4, half-maximal effective concentration: 0.238 nM
Compound 4: the middle estimate sits 6.3-fold (0.80 log units) above what was measured; measured number below the stated range.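

Adding this group to an amine nitrogen gives a higher number on both cores, but on the core of compound 3 the step in this assay is much smaller: a 3.6-fold higher number from compound 3 to compound 4 (0.56 log units; beyond the scatter). The direction of the change therefore carries over between the two pairs, while its size does not, and the gap between the steps is larger than repeat measurements would account for: the same change on two cores in this assay, a 23-fold higher number (1.36 log units; beyond the scatter) from compound 1 to compound 2 and a 3.6-fold higher number (0.56 log units; beyond the scatter) from compound 3 to compound 4, 6.4-fold (0.81 log units) apart, beyond the scatter of two such steps

Among these compounds, with only two pairs, this shows that a step measured on one core cannot simply be transferred at full size to the other, but it does not show which structural difference between the cores matters, why the steps differ, or what size to expect on a third core.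

The compounds shown leave open whether a smaller group on the same amine nitrogen, such as a methyl or an acetyl, would also give different steps on the two cores. They also leave open how the step would behave on a core with a shorter or longer chain.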